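The compounds below may be only part of what the source reports. "The series", "measured", "known", "first", "only" and "open" are said of these compounds alone.

Compound 1 is `COc1ccccc1C(=O)Nc1ccc(Cl)cc1F`. In an ADME assay on RAW264.7 cells (Mus musculus) for cytotoxicity, read by MTT assay, with a stated time of 24 h (a higher number here means that more compound is tolerated, a lower number that less compound is tolerated), compound 1 gives > 40000 nM, which is a limit of the assay rather than a number. A second compound, compound 2, is `O=C(Nc1ccc(Cl)cc1F)c1ccccc1OCc1ccc(F)cc1F`. In this assay compound 2 gives > 40000 nM, again a limit of the assay. The step that the two limits leave unreadable from compound 1 to compound 2 is therefore unreadable because both of its ends rest at the limit of > 40000 nM in this assay, at which 2 of the 2 values shown sit. On the numbers shown, compound 1 thus stands only at a limit, with no numeric value to place it against another compound.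

The unmeasured compound, compound 3, is `COc1ccccc1C(=O)Nc1ccc(I)cc1F`. For the measured compounds named here, it differs from compound 1 by iodo in place of chloro on an aromatic carbon, and the one measured step does not touch this part of the core of compound 1. That step has no readable size, and both measured values sit at the same limit, so no step beyond the scatter is expected in this assay in either direction. For compound 3 the estimate in this assay is 50000 nM, with a range from 20000 nM to 120000 nM, and the expected step that the limit leaves unreadable from compound 1 to compound 3 is taken to lie within the scatter.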

Compound 3, half-maximal cytotoxic concentration: > 40000 nM
Compound 3 was reported as a limit (the forecaster's own chance of this, stated with the estimate: 75%); the middle value does not contradict the limit.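

In this assay compound 3 gives > 40000 nM, which is a limit of the assay and not a number. No step can be read between compound 1 and compound 3, because both rest at the same limit: the limit of > 40000 nM in this assay, at which 3 of the 3 values shown sit.

The compounds shown leave open at what concentration any of them becomes cytotoxic, and whether iodo in place of chloro changes that concentration.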